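This account rests on a few compounds, and the source may have more. Where it says the series, first, only, none or still open, it means among the compounds named here.

Measured so far:
compound 1, `COc1ccc(C(=O)/C=C/c2ccc(N(C)C)cc2)c2c1C=CC(C)(C)O2` — 730 nM
compound 2, `CCN(CC)c1ccc(/C=C/C(=O)c2ccc(OC)c3c2OC(C)(C)C=C3)cc1` — 590 nM
compound 3, `COc1ccc(C(=O)/C=C/c2ccc(N3CCCC3)cc2)c2c1C=CC(C)(C)O2` — 4740 nM

In a functional assay on HepG2 cells (Homo sapiens) for antiproliferative activity, read by MTT assay, with a stated time of 24 h (on this read-out lower numbers stand for stronger inhibition and higher numbers for weaker inhibition), compound 1 gives 730 nM, the second highest of the three numbers. Compound 2 is nearest, with a 1.2-fold lower number from compound 1 to compound 2 (0.09 log units; within the scatter). Compound 3 is furthest, with a 6.5-fold higher number from compound 1 to compound 3 (0.81 log units; beyond the scatter); between the other pair the gap is an 8.0-fold higher number from compound 2 to compound 3 (0.90 log units; beyond the scatter). Within this small set the amine-bearing position on the aryl ring is the only place varied, and the ring-closed amine of compound 3 is the only change that moved the number beyond the scatter.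

Compound 4, `COc1ccc(C(=O)/C=C/c2cccc(Cl)c2)c2c1C=CC(C)(C)O2`, takes a different route: 3-chlorophenyl in place of 4-(dimethylamino)phenyl on a double-bonded chain carbon bound to a double-bonded chain carbon. Within the data shown here, no measured step bears on this directly. The steps from compound 1 to compound 2 and from compound 1 to compound 3 each keep an amine on the ring and alter only its substituents; none removes it or brings in a halogen, and none shifts the substitution pattern of the ring. The one hint is that this end of the molecule is sensitive, shown by the step from compound 1 to compound 3. Among the measured compounds shown here, with no closer precedent, the expectation leans towards a weaker result, held loosely. For compound 4 the estimate is 2500 nM, within 600 nM to 10000 nM, meaning an expected step of a 3.4-fold higher number from compound 1 to compound 4 (0.53 log units; beyond the scatter).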

Compound 4, half-maximal inhibitory concentration: > 10000 nM
Compound 4 ended at the assay's limit; the forecaster's own chance of this, stated with the estimate: 10%; middle value at least 4.0-fold (0.60 log units) away from the limit.
By their numbers in this assay, from the lowest: compounds 2 and 1 (each within the scatter of the next); then compound 3. At a limit, above all of these: compound 4.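

In this assay compound 4 gives > 10000 nM, which is a limit of the assay and not a number: the limit of > 10000 nM in this assay, at which 1 of the 4 values shown sits.

Replacing 4-(dimethylamino)phenyl with 3-chlorophenyl gives an at least 13-fold higher number from compound 1 to compound 4 (1.13 log units; beyond the scatter), so this position can lose activity by more than the amine variations showed, the widest of those being an 8.0-fold higher number from compound 2 to compound 3 (0.90 log units; beyond the scatter). Among these compounds, the single exchange removes the amine, brings in chlorine and alters the substitution pattern all at once, and the result cannot assign the loss to any one of these.

Unsubstituted phenyl, 4-chlorophenyl and 3-(dimethylamino)phenyl at this position would separate those three changes, and the limit leaves open how far compound 4 actually lies from compound 1. Piperidin-1-yl and morpholin-4-yl would show whether the step of a 6.5-fold higher number from compound 1 to compound 3 (0.81 log units; beyond the scatter) extends to other ring-closed amines or stays specific to pyrrolidin-1-yl.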